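The compounds below may be only part of what the source reports. "The series", "measured", "known", "first", "only" and "open" are said of these compounds alone.

Working notes on the series. Three members of the shared core have been run in a functional assay on NCI-H322 cells (Homo sapiens) for cytotoxicity, read by MTT assay, with a stated time of 24 h; a higher number here means a weaker inhibitor, a lower number a stronger inhibitor. Compound 1 `COc1ccc(/C=C\C(=O)O)c(OCc2cn(-c3ccc(NC(C)=O)cc3)nn2)c1CC=C(C)C` gives 45700 nM. Compound 2 `COc1ccc(/C=C\C(=O)O)c(OCc2cn(-c3ccc(CO)cc3)nn2)c1CC=C(C)C` gives 27100 nM. Compound 3 `COc1ccc(/C=C\C(=O)O)c(OCc2cn(-c3ccccc3I)nn2)c1CC=C(C)C` gives 42300 nM. Within the data shown here, on these numbers compound 3 stands second highest of the three, with compound 1 nearest and compound 2 furthest; the steps of a 1.1-fold lower number from compound 1 to compound 3 (0.03 log units; within the scatter) and a 1.6-fold higher number from compound 2 to compound 3 (0.19 log units; within the scatter) both lie within the scatter, as does a 1.7-fold lower number from compound 1 to compound 2 (0.23 log units; within the scatter), so no member of the trio can be set apart from another.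

The next member, compound 4 `COc1ccc(/C=C\C(=O)O)c(OCc2cn(-c3nc4ccccc4s3)nn2)c1CC=C(C)C`, differs from compound 3 by one change: 1,3-benzothiazol-2-yl in place of 2-iodophenyl on an aromatic nitrogen. The measured steps that bear on this are the two earlier exchanges of the group on that aromatic nitrogen, a 1.1-fold lower number from compound 1 to compound 3 (0.03 log units; within the scatter) and a 1.6-fold higher number from compound 2 to compound 3 (0.19 log units; within the scatter), neither of which moved the number beyond the scatter. Among the measured compounds shown here, the exchange here is of the same kind, a change of the group on the aromatic nitrogen, and nothing measured so far shows such a change to matter in this assay. The step of a 1.1-fold lower number from compound 3 to compound 4 (0.02 log units; within the scatter) is therefore expected to stay within the scatter, with no direction favoured. Compound 4 is estimated at 40000 nM in this assay, within a range from 15000 nM to 100000 nM.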

Compound 4, half-maximal inhibitory concentration: 23000 nM
Compound 4: middle estimate off by 1.7-fold (0.24 log units), on the high side; low and high end bracket the measured number.
By their numbers in this assay, from the lowest: compounds 4, 2, 3 and 1 (each within the scatter of the next).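

Unlike the three earlier groups on this aromatic nitrogen, each with a single six-membered aromatic ring of carbon only, 1,3-benzothiazol-2-yl brings a five-membered aromatic ring with 2 hetero atoms alongside its six-membered ring, yet the number in this assay stays within the scatter of all three compounds (a 1.8-fold lower number from compound 3 to compound 4 (0.26 log units; within the scatter); a 1.2-fold lower number from compound 2 to compound 4 (0.07 log units; within the scatter); a 2.0-fold lower number from compound 1 to compound 4 (0.30 log units; within the scatter)). The range of groups tolerated at this position without a change beyond the scatter therefore now extends to a group with two aromatic rings and, against 2-iodophenyl, a move from 0 to 2 hydrogen-bond acceptors on the group. No supporting measurement accompanies these numbers to account for them.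

On these data alone, whether an amine or a carboxylic acid on the aromatic group, or a longer alkyl chain in place of that group on the aromatic nitrogen, would move the number beyond the scatter stays open. All four compounds share the rest of the core, so the compounds shown also leave open whether a change anywhere else on it matters in this assay at all.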